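Replacing thiophen-2-yl with 1,3-thiazol-2-yl on a shared core

The source may hold more compounds than are shown below. What is called first, only, known or untested is meant among the compounds shown, and "the series" means these compounds.

Three compounds measured in a functional assay on PC-3 cells (Homo sapiens) for cytotoxicity; a lower number here means that less compound is needed, a higher number that more compound is needed for the effect:
Compound 1 `COC1=C(C)C(=O)/C(=C(O)/C=C/c2ccc(OC)cc2)C(=O)C1(C)C` gives 18.2 ug/mL
Compound 2 `COC1=C(C)C(=O)/C(=C(O)/C=C/c2cccc(OC)c2)C(=O)C1(C)C` gives 14.3 ug/mL
Compound 3 `COC1=C(C)C(=O)/C(=C(O)/C=C/c2cccs2)C(=O)C1(C)C` gives 18.2 ug/mL

Compound 3 stands level with the first of these (no change at the digits printed from compound 1 to compound 3 (within the scatter)) and close to the second (a 1.3-fold higher number from compound 2 to compound 3 (0.10 log units; within the scatter)), all within the usual scatter. Still unmeasured is compound 4 `COC1=C(C)C(=O)/C(=C(O)/C=C/c2nccs2)C(=O)C1(C)C`, which has 1,3-thiazol-2-yl in place of thiophen-2-yl on a double-bonded chain carbon bound to a double-bonded chain carbon and is otherwise the same.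

Among the measured compounds shown here, no measured step makes this exact exchange. For the measured compounds named here, the only guidance comes from the other exchanges at the same place, which include 3-methoxyphenyl in place of 4-methoxyphenyl (a 1.3-fold lower number from compound 1 to compound 2 (0.10 log units; within the scatter)). Each of them stayed within the scatter, but three compounds are a thin basis. No shift beyond the scatter is therefore expected in this assay, and no direction is favoured, so the expected change is small: a 1.0-fold lower number from compound 3 to compound 4 (0.00 log units; within the scatter). For compound 4 the estimated value is 18 ug/mL, with the measurement expected between 10 ug/mL and 32 ug/mL.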

Compound 4, concentration for half-maximal effect: 10.8 ug/mL
For compound 4 the middle estimate is 1.7-fold (0.22 log units) above the measured one, and the stated range covers the measured number.
By their numbers in this assay, from the lowest: compounds 4, 2, 1 and 3 (each within the scatter of the next).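

Compound 4 is the only one here with a five-membered aromatic ring holding 2 hetero atoms at this place, and in this assay the exchange of thiophen-2-yl for 1,3-thiazol-2-yl stays within the scatter (a 1.7-fold lower number from compound 3 to compound 4 (0.23 log units; within the scatter)). Set against the two methoxyphenyl compounds, the new group also stays within the scatter (a 1.3-fold lower number from compound 2 to compound 4 (0.12 log units; within the scatter); a 1.7-fold lower number from compound 1 to compound 4 (0.23 log units; within the scatter)), so all four groups at this place read alike in this assay, and no measurement is available to explain the values.

The compounds shown leave open whether any group on this double-bonded chain carbon can move the number beyond the scatter, for instance an amine, a carboxylic acid or a longer chain in place of the ring. They also leave open whether the exchange would read the same way on other cell lines.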